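The source may report more compounds than this note shows. Statements on the series, on what has been measured and on what is new or still open speak of the compounds shown alone.

The measured compounds:
compound 1, `N#C/C(=C\c1c(F)c(F)c(F)c(F)c1F)C(=O)c1ccc[nH]1`: 25000 nM
compound 2, `N#C/C(=C\c1ccc([N+](=O)[O-])cc1)C(=O)c1c[nH]c2ccccc12`: 46000 nM
compound 3, `COc1ccc(CNC(=O)/C(C#N)=C/c2ccc(C)o2)cc1`: 51000 nM

Three compounds were tested in a functional assay on MIA cells (Homo sapiens) for inhibition, read by MTT assay, with a stated time of 72 h; a higher number here means a weaker inhibitor of growth, a lower number a stronger inhibitor of growth. Compound 1 gives 25000 nM, compound 2 gives 46000 nM, and compound 3 gives 51000 nM. Of these three numbers, compound 3 has the highest. Its number and that of compound 2 lie within the usual scatter of repeated measurements of each other, so no order between those two can be read from them; the gap between compound 3 and compound 1 lies beyond the scatter, with compound 1 showing the lower number.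

Compound 4, `COc1ccc(CNC(=O)/C(C#N)=C/c2ccc(C)cc2)cc1`, has not been measured. It differs from compound 3 in one place: 4-methylphenyl in place of 5-methylfuran-2-yl on a double-bonded chain carbon bound to a double-bonded chain carbon. Going by the values given here, the three measured compounds differ from one another in several places at once, so no single change has been measured on its own, and there is no step between measured compounds to lean on for this one. All three numbers sit in the same weak region of this assay. On that basis compound 4 is expected to stay close to compound 3. The expected step is a 1.1-fold higher number from compound 3 to compound 4 (0.03 log units; within the scatter), not beyond the scatter in either direction. The estimate for compound 4 in this assay is 55000 nM, with a range from 20000 nM to 150000 nM.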

Compound 4, concentration for 50% growth inhibition: 38000 nM
Compound 4: the middle estimate sits 1.4-fold (0.16 log units) above what was measured, and the stated range covers the measured number.
By their numbers in this assay, from the lowest: compounds 1, 4, 2 and 3 (each within the scatter of the next, the first and the last beyond it).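

Going by these compounds alone, this is the first change in this assay that can be read on its own: placing 4-methylphenyl where 5-methylfuran-2-yl stood, on a double-bonded chain carbon bound to a double-bonded chain carbon, gives a 1.3-fold lower number from compound 3 to compound 4 (0.13 log units; within the scatter), so the two numbers cannot be told apart. At this place, then, a five-membered aromatic ring with one hetero atom and a six-membered aromatic ring of carbon only give the same growth inhibition as far as this assay can show, even though the oxygen, the one hydrogen-bond acceptor in the group, is gone. Nothing available explains why the swap leaves the number within the scatter.

This is a single pair, so the compounds shown leave open whether the same swap would behave alike on the cores of compound 1 and compound 2. They also leave open whether a different group at this place, such as a ring carrying an amine or a carboxylic acid, or a longer chain instead of a ring, would move the number beyond the scatter.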